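A few compounds are considered here, and "the series" means these few. Any claim that something is new, unique, unknown or untested is made for them only; others in the source may bear on it.

Measured so far in an assay on Sf9 cells for inhibition of protein deacetylase HDAC6 (Homo sapiens), read by fluorescence, with a stated time of 40 min; a lower number here means a stronger inhibitor, a higher number a weaker inhibitor:
compound 1, `COc1ccc(-n2nc(-c3ccccc3)nc2CNc2ccc(C(=O)NO)cc2)cc1`: 127 nM
compound 2, `COc1ccc(-c2nc(CNc3ccc(C(=O)NO)cc3)n(-c3ccccc3)n2)cc1`: 163 nM
compound 3, `O=C(NO)c1ccc(NCc2nc(-c3ccccc3)nn2-c2cccc(Cl)c2)cc1`: 678 nM

Compound 2 gives the second highest of the three numbers. Against compound 1 the gap is within the scatter, so no order between compound 2 and compound 1 can be read; against compound 3 the gap is beyond the scatter, and compound 3 carries the higher number of the two.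

Compound 4, `Cc1ccsc1-c1nc(CNc2ccc(C(=O)NO)cc2)n(-c2ccccc2)n1`, is not yet measured. It differs from compound 2 in one place: 3-methylthiophen-2-yl in place of 4-methoxyphenyl on an aromatic carbon.

Within the data shown here, the only measured step that changes a single group is a 5.3-fold higher number from compound 1 to compound 3 (0.73 log units; beyond the scatter). That step swaps the group on an aromatic nitrogen of the shared core, not the group on the aromatic carbon changed here, so it serves only as a rough guide to how far one ring substituent can move the number in this assay. Among the measured compounds shown here, no measured pair touches the aromatic-carbon group. For the measured compounds named here, the expected step is a 1.5-fold higher number from compound 2 to compound 4 (0.19 log units; within the scatter), within the scatter or at most a modest rise, on the basis of the single measured step of a 5.3-fold higher number from compound 1 to compound 3 (0.73 log units; beyond the scatter) alone. The estimate for compound 4 in this assay is 250 nM, range 100 nM to 700 nM.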

Compound 4, half-maximal inhibitory concentration: 30.7 nM
Estimate against measurement, compound 4: 8.1-fold (0.91 log units) above; the whole stated range lies above it.
By their numbers in this assay, from the lowest: compound 4; then compounds 1 and 2 (each within the scatter of the next); then compound 3.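

In this assay, the aromatic carbon of the shared core now has a measured single-place change: 3-methylthiophen-2-yl in place of 4-methoxyphenyl gives a 5.3-fold lower number from compound 2 to compound 4 (0.73 log units; beyond the scatter) as the step at this position. Among these compounds, the only earlier single-place change lay on an aromatic nitrogen and raised the number, as a 5.3-fold higher number from compound 1 to compound 3 (0.73 log units; beyond the scatter) shows, so this is the first step to lower it, and it does so with the entering group holding 6 heavy atoms against 8 in the group that leaves. Nothing measured here bears on why the number falls.

Still open, from the compounds shown here alone, is which part of the exchange carries the step: the sulfur-containing five-membered ring, its methyl group, or the loss of the methoxy group, a question that unsubstituted thiophen-2-yl or 2-methylphenyl at this carbon would help to separate. Also open, going by these compounds, is how far this position accepts other kinds of group, such as a carboxylic acid or an amine, and whether 3-methylthiophen-2-yl keeps its effect alongside 3-chlorophenyl on the aromatic nitrogen.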